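Removing a Methoxy Group: Expected Effect on Cell Toxicity

The source may report more compounds than this note shows. Statements on the series, on what has been measured and on what is new or still open speak of the compounds shown alone.

Compound 2 `COc1ccc(-c2cs/c(=N/NC(=O)CSc3nnnn3C)n2-c2ccccc2)cc1` gives 45 ug/mL in an ADME assay on NIH3T3 cells (Mus musculus) for cytotoxicity, read by MTT assay, with a stated time of 24 h (on this read-out higher numbers stand for weaker inhibition and lower numbers for stronger inhibition), the second highest of the three numbers measured. Compound 1 `COc1ccc(-c2cs/c(=N/NC(=O)CSc3nnnn3-c3ccccc3)n2-c2ccccc2)cc1` gives 11.7 ug/mL in this assay, and compound 3 `COc1ccc(-c2cs/c(=N/NC(=O)CSc3ncccn3)n2-c2ccccc2)cc1` gives 450 ug/mL. The measured steps, a 3.8-fold higher number from compound 1 to compound 2 (0.59 log units; beyond the scatter), a 38-fold higher number from compound 1 to compound 3 (1.59 log units; beyond the scatter) and a 10-fold higher number from compound 2 to compound 3 (1.00 log units; beyond the scatter), all change the group attached to the sulfur. Compound 4 `Cn1nnnc1SCC(=O)N/N=c1/scc(-c2ccccc2)n1-c1ccccc1` differs from compound 2 at a different place: hydrogen in place of methoxy on an aromatic carbon. Among the compounds with values here, no measured step touches this place, so the data give nothing to set a direction. The expected step of no change at the digits printed from compound 2 to compound 4 (within the scatter) is therefore none beyond the scatter, with a wide range to reflect the lack of precedent. Compound 4 is estimated to give 45 ug/mL, between 15 ug/mL and 135 ug/mL.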

Compound 4, half-maximal inhibitory concentration: 173 ug/mL
Beside the measured number, compound 4's estimate is 3.8-fold (0.58 log units) below it, outside the stated range (above it).
By their numbers in this assay, from the lowest: compound 1; then compound 2; then compound 4; then compound 3.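

The methoxy group is not a silent bystander in this assay: removing it, so that 4-methoxyphenyl becomes phenyl, gives a 3.8-fold higher number from compound 2 to compound 4 (0.58 log units; beyond the scatter), a shift beyond the usual scatter. The group on the sulfur is therefore not the only part of these compounds that moves the number, and with methoxy present the inhibition is stronger. No measurement here explains why the number moves.

On these data alone, it remains open whether the same change would act alike in compound 1 or compound 3. Also open, as far as these compounds go, is how an amine or an ethoxy group on that aromatic carbon would compare.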